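Swapping a Dichlorophenyl onto a Piperidine Sulfonamide

The source may hold more compounds than are shown below. What is called first, only, known or untested is meant among the compounds shown, and "the series" means these compounds.

Compound 1 `COc1ccc(S(=O)(=O)N2CCC(N3CCC(C)CC3)CC2)cc1OC` gives > 5000 nM in an ADME assay on HCT-116 cells (Homo sapiens) for cytotoxicity, read by CellTiter-Glo, with a stated time of 72 h; a higher number here means a weaker inhibitor, a lower number a stronger inhibitor; this is a limit of the assay, not a number.
Compound 2 `Cc1ccc(S(=O)(=O)N2CCC(N3CCC(C)CC3)CC2)cc1C` gives > 5000 nM in this assay, again a limit.
Compound 3 `Cc1ccc(C2CCN(S(=O)(=O)c3c(C)cc(C)cc3C)CC2)cc1` gives > 5000 nM in this assay, also a limit.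

Compound 2 thus stands at the limit, as do both other measured compounds, which is what the limit of > 5000 nM in this assay, at which 3 of the 3 values shown sit, records. Compound 4 `CC1CCN(C2CCN(S(=O)(=O)c3cc(Cl)cc(Cl)c3)CC2)CC1` differs from compound 2 in a single place: 3,5-dichlorophenyl in place of 3,4-dimethylphenyl on a sulfonyl sulfur. Among the compounds with values here, no measured step between compounds is available to gauge this change. No step beyond the usual scatter is expected in this assay in either direction, because compound 2 already sits at the limit of > 5000 nM in this assay, at which 3 of the 3 values shown sit. Compound 4 is therefore estimated at 8000 nM, with a range from 3000 nM to 30000 nM. The expected step is a step that the limit leaves unreadable from compound 2 to compound 4.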

Compound 4, half-maximal inhibitory concentration: > 5000 nM
Compound 4: no number, only a limit (the forecaster's own chance of this, stated with the estimate: 80%); the middle value lies beyond the limit too.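

No step can be read from compound 2 to compound 4 in this assay, since both give only a limit: the limit of > 5000 nM in this assay, at which 4 of the 4 values shown sit.

The compounds shown leave open whether 3,5-dichlorophenyl in place of 3,4-dimethylphenyl changes potency at all.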